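A New Phenyl Group on the Shared Core

The compounds below may be only part of what the source reports. "The series", "measured", "known", "first", "only" and "open" are said of these compounds alone.

In a functional assay on A549 cells (Homo sapiens) for inhibition, read by MTT assay, with a stated time of 48 h (on this read-out lower numbers stand for stronger inhibition and higher numbers for weaker inhibition), compound 1 (`Cc1ccc(NC(=O)Nc2cccc(-c3cccc4[nH]nc(N)c34)c2)cc1`) gives 1660 nM and compound 2 (`Nc1n[nH]c2cccc(-c3cccc(NC(=O)Nc4ccc(F)c(F)c4)c3)c12`) gives 3040 nM so the two lie within the scatter of each other. Compound 3 (`CC(C)c1cccc(NC(=O)Nc2cccc(-c3cccc4[nH]nc(N)c34)c2)c1`) keeps the shared core and differs from compound 2 in one group (3-isopropylphenyl in place of 3,4-difluorophenyl on an amide-type nitrogen) with 3-isopropylphenyl in place of 3,4-difluorophenyl on an amide-type nitrogen. Going by the values given here, the only measured step that bears on this is a 1.8-fold higher number from compound 1 to compound 2 (0.26 log units; within the scatter) at that same place, and it stayed within the scatter. No step beyond the scatter is therefore expected in this assay here. The estimated step is a 1.4-fold lower number from compound 2 to compound 3 (0.14 log units; within the scatter) and it is only an expectation. Compound 3 is expected at 2200 nM with an estimated range from 800 nM to 6000 nM in this read-out.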

Compound 3, half-maximal inhibitory concentration: 1420 nM
Compound 3: the middle estimate sits 1.5-fold (0.19 log units) above what was measured; low and high end bracket the measured number.
By their numbers in this assay, from the lowest: compounds 3, 1 and 2 (each within the scatter of the next, the first and the last beyond it).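

In this assay, going by these compounds alone, swapping the aryl group on this amide-type nitrogen now gives a real, though modest, change, with a 2.1-fold lower number from compound 2 to compound 3 (0.33 log units; beyond the scatter) as the first step to pass the scatter. By contrast, a 1.2-fold lower number from compound 1 to compound 3 (0.07 log units; within the scatter) shows that 3-isopropylphenyl and 4-methylphenyl cannot be told apart here. Nothing measured here explains the difference between these groups. Still open, as far as these compounds go, is whether a phenyl carrying an amine or a carboxylic acid at this place would shift the number much further, in either direction.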